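The compounds below may be only part of what the source reports. "The series", "measured", "known", "first", "only" and "open" are said of these compounds alone.

Measured so far in a functional assay on MCF7 cells (Homo sapiens) for antiproliferative activity; on this read-out higher numbers stand for weaker inhibition and lower numbers for stronger inhibition:
- Compound 1 `CO[C@@H]1[C@@H](O)[C@@H](O)[C@H](Oc2ccc3c(c2C)OC(=O)C(n2cc(-c4ccccc4)nn2)C3)OC1(C)C`: 64400 nM
- Compound 2 `CO[C@@H]1[C@@H](O)[C@@H](O)[C@H](Oc2ccc3c(c2C)OC(=O)C(n2cc(-c4ccc(C)cc4)nn2)C3)OC1(C)C`: > 100000 nM (a limit, not a number)
- Compound 3 `CO[C@@H]1[C@@H](O)[C@@H](O)[C@H](Oc2ccc3c(c2C)OC(=O)C(n2cc(-c4ccc(F)cc4F)nn2)C3)OC1(C)C`: > 100000 nM (a limit, not a number)

Compound 3 has no exact value, only the limit of > 100000 nM. Compound 3 and compound 2 share (the limit of > 100000 nM in this assay, at which 2 of the 3 values shown sit). Only compound 1, with its plain phenyl, gives a true number.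

The next compound is compound 4 `CO[C@@H]1[C@@H](O)[C@@H](O)[C@H](Oc2ccc3c(c2C)OC(=O)C(n2cc(-c4ccc(N(C)C)cc4)nn2)C3)OC1(C)C`. The change is 4-(dimethylamino)phenyl in place of 2,4-difluorophenyl on an aromatic carbon: 4-(dimethylamino)phenyl in place of 2,4-difluorophenyl, on an aromatic carbon of the five-membered aromatic ring with 3 nitrogen.

Going by the values given here, two measured steps bear most directly on this change, since both replace the plain phenyl with a substituted one. They are an at least 1.5-fold higher number from compound 1 to compound 2 (0.19 log units; that floor lies within the scatter) and an at least 1.5-fold higher number from compound 1 to compound 3 (0.19 log units; that floor lies within the scatter). From the compounds shown here alone, both are only floors, so their true sizes remain unknown. The comparison of the two substituted compounds gives a step that the two limits leave unreadable from compound 2 to compound 3, so it offers no guide to how much the choice of substituent matters.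

With so little to go on, no change beyond the scatter is expected in this assay, and the expected step is a number no higher from compound 3 to compound 4 (the limit leaves the size open). Compound 4 may well report only a limit again. The estimate for compound 4 is 100000 nM, with an expected range from 40000 nM to 250000 nM.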

Compound 4, half-maximal inhibitory concentration: > 100000 nM
Compound 4: no number, only a limit; the forecaster's own chance of this, stated with the estimate: 60%; the middle value sits exactly at the limit.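

In this assay, the 4-(dimethylamino)phenyl group on the five-membered ring ends up at the same limit as 4-methylphenyl and 2,4-difluorophenyl, so a third substituted phenyl, this one bringing a nitrogen and a hydrogen-bond acceptor, also gives no true number: the limit of > 100000 nM in this assay, at which 3 of the 4 values shown sit.

Against the plain phenyl of compound 1, the one readable step is an at least 1.5-fold higher number from compound 1 to compound 4 (0.19 log units; that floor lies within the scatter), and this is only a floor, so the true size stays unknown. The steps among compound 2, compound 3 and compound 4 cannot be read: each joins two limits, and these three compounds cannot be ranked against one another.

Still open, from the compounds shown here alone, is whether any substituted phenyl at this place can give a true number in this assay, for example one carrying a hydroxyl or a carboxylic acid, and whether a short alkyl chain in place of the whole phenyl would do so. Going by these compounds, it also remains open how far beyond the limit the true values of compound 2, compound 3 and compound 4 lie.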